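This account rests on a few compounds, and the source may have more. Where it says the series, first, only, none or still open, it means among the compounds named here.

Working notes on the series. Among the compounds with values here, compound 2 `CC(C)(C)c1ccc(C(=O)N2CCC3(CC2)C(=O)N(CC(=O)NCCCCCNS(C)(=O)=O)CN3c2ccccc2)cc1` gives 5500 nM in an assay on HEK293 cells for displacement of a labelled ligand from NPC1-like intracellular cholesterol transporter 1 (Homo sapiens); on this read-out higher numbers stand for weaker inhibition and lower numbers for stronger inhibition; the only other measured member, compound 1 `CC(C)(C)OC(=O)NCCCNC(=O)CN1CN(c2ccccc2)C2(CCN(C(=O)c3ccc(C(C)(C)C)cc3)CC2)C1=O`, gives 4500 nM in this assay. Within the data shown here, the two numbers lie within the scatter of each other, and the one measured step, a 1.2-fold higher number from compound 1 to compound 2 (0.09 log units; within the scatter), is a change at the far end of the chain with no effect beyond the noise.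

Compound 3 `CC(C)(C)c1ccc(C(=O)N2CCC3(CC2)C(=O)N(CC(=O)N2CCC(O)CC2)CN3c2ccccc2)cc1` is the next member. Its change from compound 2 is 4-hydroxypiperidin-1-yl in place of (5-(methanesulfonamido)pentyl)amino on a carbonyl carbon. This removes the whole chain and its terminal group and closes the amide nitrogen into a ring, so it reaches further than the step from compound 1 to compound 2, which only swapped the group at the chain end. That step is the only one that bears on it, and it shows the chain end to be tolerant; nothing measured speaks to loss of the chain itself. The expected step of a 1.1-fold lower number from compound 2 to compound 3 (0.04 log units; within the scatter) is therefore none beyond the scatter, with wide uncertainty. For compound 3 the estimate in this assay is 5000 nM, with a range from 1500 nM to 16000 nM.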

Compound 3, half-maximal inhibitory concentration: 4700 nM
The estimate for compound 3 lay 1.1-fold (0.03 log units) above the measured number; the range from low to high includes it.
By their numbers in this assay, from the lowest: compounds 1, 3 and 2 (each within the scatter of the next).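

The position on the carbonyl carbon accepts a ring as well as an open chain: in this assay, 4-hydroxypiperidin-1-yl in place of (5-(methanesulfonamido)pentyl)amino gives a 1.2-fold lower number from compound 2 to compound 3 (0.07 log units; within the scatter), and the same ring in place of (3-((tert-butoxycarbonyl)amino)propyl)amino gives a 1.0-fold higher number from compound 1 to compound 3 (0.02 log units; within the scatter). The earlier step touched only the far end of the chain, whereas these two steps show that neither the chain, its terminal group nor the amide hydrogen is needed for a number of this size, even with fewer heavy atoms entering than leave compound 2. No measurement bears on why the numbers show so little response to these replacements.

All three compounds lie within the scatter of one another, so no group shown at this carbonyl carbon separates itself from the others on this read-out. Open, from the compounds shown here alone, is whether a group such as piperazin-1-yl, piperidin-1-yl without the hydroxyl, or a chain ending in a carboxylic acid or a primary amine would give a step beyond the scatter, and whether the phenyl or the 4-tert-butylbenzoyl group on the shared core is equally tolerant of replacement.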